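Terminal Aryl Exchange on a Bile Acid Receptor Binder

The source may hold more compounds than are shown below. What is called first, only, known or untested is meant among the compounds shown, and "the series" means these compounds.

Compound 1 `COC(=O)/C=C/c1cccc(N(Cc2ccc(-c3ccc(OC)cc3)cc2)C(=O)C(C)C)c1` gives 97 nM in an assay on isolated protein with Bile acid receptor (Homo sapiens) as the target; on this read-out higher numbers stand for an effect only at larger amounts of compound and lower numbers for an effect already at smaller amounts.
Compound 2 `COC(=O)/C=C/c1cccc(N(Cc2ccc(-c3ccc(OC(F)(F)F)cc3)cc2)C(=O)C(C)C)c1` gives 219 nM in this assay.

Among the measured compounds shown here, compound 2 stands at the highest of the two numbers seen so far; its nearest neighbour is compound 1, and the only measured step is a 2.3-fold higher number from compound 1 to compound 2 (0.35 log units; beyond the scatter). Compound 3 `COC(=O)/C=C/c1cccc(N(Cc2ccc(-c3c(OC)cccc3OC)cc2)C(=O)C(C)C)c1` has not been measured in this assay. It differs from compound 2 by 2,6-dimethoxyphenyl in place of 4-(trifluoromethoxy)phenyl on an aromatic carbon. For the measured compounds named here, the one measured step bears on this change only in part: it shows that returning from trifluoromethyl to methyl on the oxygen lowered the number, and compound 3 again carries methoxy groups, yet in a new arrangement with two of them, for which no step exists. The expectation is therefore a move back toward the number of compound 1, with wide uncertainty. For compound 3 the estimate in this assay is 180 nM, with a range from 55 nM to 600 nM, which is expected to amount to a 1.2-fold lower number from compound 2 to compound 3 (0.09 log units; within the scatter).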

Compound 3, half-maximal effective concentration: 95 nM
For compound 3 the middle estimate is 1.9-fold (0.28 log units) above the measured one; measured number inside the range.
By their numbers in this assay, from the lowest: compounds 3 and 1 (each within the scatter of the next); then compound 2.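

Replacing 4-(trifluoromethoxy)phenyl with 2,6-dimethoxyphenyl gives a 2.3-fold lower number from compound 2 to compound 3 (0.36 log units; beyond the scatter) in this assay and thus shows that this position can take a different substitution arrangement without the number staying at the level of compound 2. The comparison with the 4-methoxyphenyl group gives a 1.0-fold lower number from compound 1 to compound 3 (0.01 log units; within the scatter) and leaves the two methoxy-bearing aryl groups indistinguishable in this assay, so the added methoxy group and the new arrangement show no separate effect here. No available evidence accounts for this result.

Going by these compounds, whether an amine or a carboxylic acid on this aryl ring would keep the number near those of compound 1 and compound 3 remains open. So does the outcome of a hydroxyl group or a longer alkoxy chain in place of methoxy.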